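Bromo to Iodo on a Dichloroacetanilide Scaffold

A few compounds are considered here, and "the series" means these few. Any claim that something is new, unique, unknown or untested is made for them only; others in the source may bear on it.

Compound 1, `O=C(Nc1ccccc1)C(Cl)Cl`: "not determined" (no result reported)
Compound 2, `O=C(Nc1ccc(Br)cc1)C(Cl)Cl`: 9770 nM

Two compounds of this series carry the same dichloroacetamide attached to an aromatic ring. Compound 1 `O=C(Nc1ccccc1)C(Cl)Cl` bears the unsubstituted ring, and for compound 1 the entry reads "not determined" (no result reported). In a functional assay on Bel-7402 cells (Homo sapiens) for antiproliferative activity, read by MTT assay, with a stated time of 72 h (on this read-out lower numbers stand for stronger inhibition and higher numbers for weaker inhibition), compound 2 `O=C(Nc1ccc(Br)cc1)C(Cl)Cl` gives 9770 nM. For the measured compounds named here, that is the only number in hand, so compound 2 stands alone, with nothing to be ranked against.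

Compound 3 `O=C(Nc1ccc(I)cc1)C(Cl)Cl` is yet to be tested. It differs from compound 2 by iodo in place of bromo on an aromatic carbon. Going by the values given here, no step between measured compounds is known in this assay, so nothing measured tells how large such a swap moves the read-out here. A change of this kind, one halogen for the next heavier one at the same place, is expected to produce a step within the usual scatter, with at most a slight lean toward stronger inhibition.

Compound 3 is therefore estimated at 7000 nM in this assay, within a range from 2500 nM to 20000 nM. The expected step of a 1.4-fold lower number from compound 2 to compound 3 (0.14 log units; within the scatter) is small.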

Compound 3, half-maximal inhibitory concentration: 11900 nM
The estimate for compound 3 lay 1.7-fold (0.23 log units) below the measured number; the range from low to high includes it.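

For the compounds shown here, this is the first measured step at this position: in this assay, iodo in place of bromo on an aromatic carbon, para to a group of 6 heavy atoms, gives a 1.2-fold higher number from compound 2 to compound 3 (0.09 log units; within the scatter) and so leaves the read-out unchanged within the usual variation of repeated measurements. Compound 2 and compound 3 therefore cannot be told apart in this read-out, and at this place the exchange of one halogen for the next heavier one, with no ring, hydrogen-bond donor, hydrogen-bond acceptor or net charge entering or leaving, does not separate the two compounds. Nothing at hand bears on why the two compounds read alike.

With only these two numbers, the series says nothing about how far this position can move the read-out when the group placed there is something other than a heavier halogen. As far as these compounds go, whether an amine, a carboxylic acid or a longer chain in place of the halogen would produce a step beyond the scatter remains open, as does the effect of changing the dichloroacetamide portion of the shared core.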